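A few compounds are considered here, and "the series" means these few. Any claim that something is new, unique, unknown or untested is made for them only; others in the source may bear on it.

In a functional assay on the whole organism with Canis familiaris (Canis lupus familiaris) as the target (on this read-out lower numbers stand for an effect already at smaller amounts and higher numbers for an effect only at larger amounts of compound), compound 1 `CCNC(=O)[C@H]1OC(n2cnc3c(NC)ncnc32)[C@H](O)[C@@H]1O` gives 0.5 nM, and compound 2 `CCNC(=O)[C@H]1OC(n2cnc3c(Nc4ccc(OC)cc4)ncnc32)[C@H](O)[C@@H]1O` gives 3.5 nM. Within the data shown here, compound 1 therefore holds the lower of the two numbers so far, and the only measured step is a 7.0-fold higher number from compound 1 to compound 2 (0.85 log units; beyond the scatter). Compound 3 `CNc1ncnc2c1ncn2C1O[C@H](C(=O)O)[C@@H](O)[C@H]1O` keeps the methyl group of compound 1 and differs from it as follows: hydroxy in place of ethylamino on a carbonyl carbon. In words, this is hydroxy in place of ethylamino on a carbonyl carbon, or ethylcarbamoyl to carboxy. Among the measured compounds shown here, no measured step touches this place. For the measured compounds named here, the one step available, a 7.0-fold higher number from compound 1 to compound 2 (0.85 log units; beyond the scatter), comes from a change elsewhere in the structure. Going by the values given here, it shows only that the number of compound 1 can move beyond the scatter, and it does not set the size of a change at the carbonyl carbon. Even so, a rise in this assay is expected, probably larger than that step, though this is a judgement with no direct comparison behind it, so the range is kept wide. The expected change is a 400-fold higher number from compound 1 to compound 3 (2.60 log units; beyond the scatter). For compound 3 the estimated value is 200 nM, within an expected range of 20 nM to 2000 nM.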

Compound 3, half-maximal effective concentration: 0.46 nM
Estimate against measurement, compound 3: 430-fold (2.64 log units) above; measured number below the stated range.
By their numbers in this assay, from the lowest: compounds 3 and 1 (each within the scatter of the next); then compound 2.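

In this assay the change from ethylcarbamoyl to carboxy gives a 1.1-fold lower number from compound 1 to compound 3 (0.04 log units; within the scatter), so at this position, on a carbonyl carbon whose other neighbour is a saturated ring carbon, hydroxy can stand in place of ethylamino with the methyl group kept and no change beyond the scatter. The earlier step, a 7.0-fold higher number from compound 1 to compound 2 (0.85 log units; beyond the scatter), came from a change elsewhere in the structure and gave no reading for this place; the series now shows one site where replacing a group leaves the number in place and another where it does not, though each rests on a single pair. Nothing measured here accounts for the ethylamino group being dispensable in this read-out.

The compounds shown leave open how other groups on the same carbonyl carbon would read in this assay, such as a plain amino group, a methoxy ester or a longer chain like propylamino. They also leave open whether carboxy keeps this behaviour when the methyl group is replaced by 4-methoxyphenyl, since that combination would show whether the two places act independently.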